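A few compounds are considered here, and "the series" means these few. Any claim that something is new, unique, unknown or untested is made for them only; others in the source may bear on it.

Working notes on the series. Compound 1 `Cc1cc(NCc2cccs2)n2nc(C)c(-c3ccccc3)c2n1`, compound 2 `COc1ccc(-c2c(C)nn3c(NCc4ccccn4)cc(C)nc23)cc1` and compound 3 `Cc1cc(NCc2ccccn2)n2ncc(-c3ccc(N(C)C)cc3)c2n1` share one core and have each been run in a physicochemical assay for solubility, read by HPLC, using the shake flask method, measured as kinetic solubility, with a stated time of 2 h, at pH 7.4; on this read-out lower numbers stand for lower solubility and higher numbers for higher solubility. Compound 1 returns only a limit of this assay, < 5000 nM. Compound 2 likewise returns only a limit, < 5000 nM. Within the data shown here, compound 3 also returns only a limit, < 5000 nM, so no number stands for it and no step between measured compounds can be computed. What the measured set shows is summed up in the limit of < 5000 nM in this assay, at which 3 of the 3 values shown sit, which places every value shown in one position, without order among the three.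

Compound 4 `Cc1cc(NCc2ccccn2)n2ncc(C3=CCOCC3)c2n1` is not yet measured. It differs from compound 3 by a group of 6 heavy atoms (5 carbon, 1 oxygen; one six-membered non-aromatic ring with 1 hetero atom) in place of a group of 9 heavy atoms (8 carbon, 1 nitrogen; one six-membered aromatic ring of carbon only), on an aromatic carbon. The entering group carries its one hydrogen-bond acceptor on an oxygen within the six-membered non-aromatic ring.

Among the measured compounds shown here, with every value at the limit, no measured step sets the size of the expected change. Compound 4 is expected to move by an at least 1.6-fold higher number from compound 3 to compound 4 (0.20 log units; that floor lies within the scatter) toward higher solubility in this assay, beyond the scatter, though a limit may be returned again. Compound 4 is estimated at 8000 nM, within 2000 nM to 40000 nM.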

Compound 4, solubility: 171000 nM
For compound 4 the middle estimate is 21-fold (1.33 log units) below the measured one; the measured number lies above the stated range.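

In this assay, among these compounds, the single change on the aromatic carbon of the five-membered ring, with 4-(dimethylamino)phenyl leaving and the six-membered non-aromatic ring with its ring oxygen entering, gives an at least 34-fold higher number from compound 3 to compound 4 (1.53 log units; beyond the scatter). From the compounds shown here alone, compound 3 gives only a limit, < 5000 nM, so that step is a floor and its full size stays unknown. This position is therefore the first place in the series where one change gives a value clear of the limit shared by the other compounds: the limit of < 5000 nM in this assay, at which 3 of the 4 values shown sit.

The compounds shown do not separate the ring oxygen from the ring double bond or from the loss of the aromatic ring, which a cyclohexenyl or a saturated tetrahydropyranyl group at this carbon would address. Going by these compounds, whether a morpholine there would give a similar value also remains open.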